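Removing the methoxy group from the biaryl series

The source may hold more compounds than are shown below. What is called first, only, known or untested is meant among the compounds shown, and "the series" means these compounds.

Compound 1 `COc1ccc(-c2c(C)cccc2C)cc1COc1ccc(CCC(=O)O)cc1` has no single number in a functional assay on CHO cells for agonist activity at Free fatty acid receptor 1 (Homo sapiens), read by FLIPR and calcium flux, with a stated time of 90 s, in the presence of a further agent that is not named here; a lower number here means that less compound is needed, a higher number that more compound is needed for the effect; for compound 1 the result stands as "not determined" (no result reported), so it sets no reference point. Compound 2 `Cc1cc(OC2CCS(=O)(=O)CC2)cc(C)c1-c1cccc(COc2ccc(CCC(=O)O)c(F)c2)c1`, a more elaborate member of the same series, gives in this assay a value of 25 nM. Compound 3 `Cc1cccc(C)c1-c1cccc(COc2ccc(CCC(=O)O)cc2)c1` differs from compound 1 by hydrogen in place of methoxy on an aromatic carbon. Among the measured compounds shown here, with no measured value for compound 1, no step can be sized or given a direction. Compound 3 is expected to give about 150 nM, estimated within a range from 40 nM to 600 nM.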

Compound 3, half-maximal effective concentration: 22 nM
The estimate for compound 3 lay 6.8-fold (0.83 log units) above the measured number; the whole stated range lies above it.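

Among the compounds shown here, compound 1 has no single number, so no step from it to compound 3 can be read. The compounds shown leave open what methoxy in place of hydrogen does to potency on this core. No supporting data bear on the result for compound 3.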